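This account rests on a few compounds, and the source may have more. Where it says the series, first, only, none or still open, it means among the compounds named here.

Compound 3 `CC(NC(=O)c1ccc(-c2ccc(NC(=O)Nc3cc(C(F)(F)F)ccc3Cl)cc2)cc1)c1ccccc1` is one of three ureas measured in a functional assay on A-375 cells (Homo sapiens) for inhibition, read by MTT assay, with a stated time of 120 h; a higher number here means a weaker inhibitor, a lower number a stronger inhibitor. Among the two numbers given, compound 3, at 16900 nM, has the highest one; compound 1 `CC(NC(=O)/C=C/Oc1ccc(NC(=O)Nc2cc(C(F)(F)F)ccc2Cl)cc1)c1ccccc1` sits nearest to it, at 16000 nM, and that gap lies within the scatter. Compound 2 `CNC(=O)/C(C)=C/c1ccc(NC(=O)Nc2ccc(Cl)c(C(F)(F)F)c2)cc1` gives only a limit in this assay, > 50000 nM, not a number; of the three values shown, one sits at that limit (the limit of > 50000 nM in this assay, at which 1 of the 3 values shown sits). Compound 4 `CC(NC(=O)c1ccc(-c2ccc(NC(=O)Nc3ccc(Cl)c(C(F)(F)F)c3)cc2)cc1)c1ccccc1`, not yet measured, is built from the same atoms as compound 3, joined differently: 4-chloro-3-(trifluoromethyl)phenyl in place of 2-chloro-5-(trifluoromethyl)phenyl on an amide-type nitrogen. For the measured compounds named here, no measured pair in this set differs in just that one place, so the size of the step is open. Compound 2 carries the 4-chloro-3-(trifluoromethyl)phenyl group and gives only a limit, but its remaining structure differs from compound 4 in more than one way, so it does not settle the question. The step from compound 3 to compound 4 is expected to be a modest one toward a lower number, a 2.4-fold lower number from compound 3 to compound 4 (0.38 log units; beyond the scatter), with a real chance of no change beyond the scatter. For compound 4 the estimate in this assay is 7000 nM, between 1500 nM and 30000 nM.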

Compound 4, half-maximal inhibitory concentration: 12800 nM
The estimate for compound 4 lay 1.8-fold (0.26 log units) below the measured number, within the range that was stated.
By their numbers in this assay, from the lowest: compounds 4, 1 and 3 (each within the scatter of the next). At a limit, above all of these: compound 2.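

In this assay, the swap of 2-chloro-5-(trifluoromethyl)phenyl for 4-chloro-3-(trifluoromethyl)phenyl on an amide-type nitrogen can now be read on its own, as a 1.3-fold lower number from compound 3 to compound 4 (0.12 log units; within the scatter) and with the same atoms joined differently. For the compounds shown here, no earlier pair differed in just this one place, so this is the first direct sign that, on this core, the number does not separate the two arrangements. Nothing shown here offers a reason for this small step.

Still open, from the compounds shown here alone, is how the number would respond to a different kind of group on that nitrogen, such as a phenyl ring carrying a carboxylic acid or an amine. Also open is whether the same swap would stay as small on the core of compound 1, for which only one of the two groups is shown.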